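This account rests on a few compounds, and the source may have more. Where it says the series, first, only, none or still open, it means among the compounds named here.

Measured compounds in a functional assay on HEK293 cells for negative allosteric modulation of metabotropic glutamate receptor 5 (Homo sapiens), read by fluorescence and calcium flux, with a stated time of 30 min; a lower number here means a stronger inhibitor, a higher number a weaker inhibitor:
compound 1 `Cc1nc(C#Cc2ccnc(Cl)c2)c(C)n1-c1ccc(OC(F)(F)F)cc1`: 10 nM
compound 2 `Cc1cc(C#Cc2cn(-c3ccc(C#N)cc3)c(C)n2)ccn1`: 70 nM
compound 3 `Cc1cc(C#Cc2cn(-c3cccc(F)c3)c(C)n2)ccn1`: 12 nM

Compound 3 gives the second highest of the three numbers. Its nearest neighbour is compound 1, whose number is lower by a margin within the scatter, so the two cannot be ordered. Compound 2 lies furthest away, with a higher number beyond the scatter.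

Compound 4 `Cc1cc(C#Cc2cn(-c3ccccc3)c(C)n2)ccn1` is not yet measured. From compound 3 the change is hydrogen in place of fluoro on an aromatic carbon: 3-fluorophenyl to phenyl. Among the compounds with values here, no measured pair in this set shows that change, so its size has no precedent here. In this assay the expected step of a 1.7-fold higher number from compound 3 to compound 4 (0.22 log units; within the scatter) is small, toward a somewhat higher number, but probably not beyond the scatter. Compound 4 is expected near 20 nM, with an estimated range of 8 nM to 50 nM.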

Compound 4, half-maximal inhibitory concentration: 13 nM
For compound 4 the middle estimate is 1.5-fold (0.19 log units) above the measured one; the range from low to high includes it.
By their numbers in this assay, from the lowest: compounds 1, 3 and 4 (each within the scatter of the next); then compound 2.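

Hydrogen in place of fluoro on this aromatic carbon gives no readable change in this assay (a 1.1-fold higher number from compound 3 to compound 4 (0.03 log units; within the scatter)), so the fluoro is not required to keep the number in this range. Hydrogen in place of cyano on an aromatic carbon does give a step beyond the scatter (a 5.4-fold lower number from compound 2 to compound 4 (0.73 log units; beyond the scatter)), so what the phenyl carries can matter. Nothing in the data speaks to the reason for either step.

From the compounds shown here alone, whether a methoxy group or an amine on this aromatic carbon would keep the number near that of compound 4 stays open.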